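The source may report more compounds than this note shows. Statements on the series, on what has been measured and on what is new or still open speak of the compounds shown alone.

Within the data shown here, in a functional assay on HeLa cells (Homo sapiens) for antiproliferative activity, read by MTT assay, with a stated time of 72 h (a higher number here means a weaker inhibitor, a lower number a stronger inhibitor), compound 2 `O=C1COc2ccc(-c3cccc(NS(=O)(=O)c4ccc(F)cc4)c3)cc2N1c1ccc(Cl)cc1` gives 35000 nM, the only actual number among the measured compounds. Compound 1 `COc1cccc(N2C(=O)COc3ccc(-c4cccc(NS(=O)(=O)c5ccc(F)cc5)c4)cc32)c1` is reported only as a limit, > 40000 nM. Compound 3 `Cc1ccc(N2C(=O)COc3ccc(-c4cnc5ccccc5c4)cc32)cc1` is likewise reported only as a limit, > 40000 nM. Compound 2 therefore stands close to the limit of > 40000 nM in this assay, at which 2 of the 3 values shown sit.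

Compound 4 `O=C1COc2ccc(-c3cccc(NS(=O)(=O)c4ccc(F)cc4)c3)cc2N1C1CC1` has not yet been measured. It carries cyclopropyl in place of 4-chlorophenyl on an amide-type nitrogen in a ring. Among the measured compounds shown here, one measured step bears on this nitrogen, an at least 1.1-fold lower number from compound 1 to compound 2 (0.05 log units; that floor lies within the scatter). Its floor lies within the scatter, and it only exchanges one substituted phenyl for another. For the measured compounds named here, no measured compound has a non-aromatic group at this place, so the data offer no direct guide to the new group. With so little evidence of a change, and with compound 2 already at 35000 nM, no shift beyond the scatter is expected in this assay. The expected step is a 1.1-fold higher number from compound 2 to compound 4 (0.06 log units; within the scatter). For compound 4 the estimated value is 40000 nM, with an expected range from 15000 nM to 80000 nM.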

Compound 4, half-maximal inhibitory concentration: > 40000 nM
Compound 4: no number, only a limit; the forecaster's own chance of this, stated with the estimate: 65%; the middle value sits exactly at the limit.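

The first non-aromatic group shown on this nitrogen, cyclopropyl in place of 4-chlorophenyl, gives in this assay an at least 1.1-fold higher number from compound 2 to compound 4 (0.05 log units; that floor lies within the scatter). The step between the two limits, from compound 1 to compound 4, cannot be read. A small non-aromatic ring on this nitrogen therefore brings no read-out clear of the limit, and the values now gather there: the limit of > 40000 nM in this assay, at which 3 of the 4 values shown sit.

The compounds shown leave open whether an amine, a carboxylic acid or a longer chain such as n-butyl on this nitrogen would give a number well clear of that limit. Among these compounds, compound 2 still holds the only actual number, and with limits for all the others the true size of any effect at this nitrogen stays unknown.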